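The compounds below may be only part of what the source reports. "The series", "measured", "known", "first", "only" and "open" are said of these compounds alone.

Measured compounds:
- compound 1, `COc1ncnc(Nc2ccc(C#N)c(OCC=C(C)C)c2)n1`: 42000 nM
- compound 2, `CC(C)=CCOc1cc(Nc2ncnc(N)n2)ccc1C#N`: 200 nM
- compound 3, `COc1cc(OC)nc(Nc2ccc(Cl)c(OCC=C(C)C)c2)n1`: 28000 nM

In an ADME assay on MT2 cells (Homo sapiens) for cytotoxicity (a higher number here means that more compound is tolerated, a lower number that less compound is tolerated), compound 1 gives 42000 nM. Compound 2 differs from compound 1 by one change, (amino in place of methoxy on an aromatic carbon), and the step is a 210-fold lower number from compound 1 to compound 2 (2.32 log units; beyond the scatter). Compound 3 gives 28000 nM in this assay; its number and that of compound 1 lie within the usual scatter of each other, while against compound 2 it stands far higher. How the core of compound 3 differs from the core of compound 1 is not broken down here.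

Compound 4, `COc1cc(N)nc(Nc2ccc(Cl)c(OCC=C(C)C)c2)n1`, has not yet been measured in this assay. It differs from compound 3 by amino in place of methoxy on an aromatic carbon. For the measured compounds named here, this is the same kind of change as the one from compound 1 to compound 2, but not the same: in compound 1 the methoxy sits on a ring with 3 nitrogen, between two ring nitrogen atoms, whereas in compound 3 it sits on a ring with 2 nitrogen, next to the ring nitrogen and meta to a methoxy group.

Going by the values given here, the expectation for compound 4 rests on the single earlier step, which was a 210-fold lower number from compound 1 to compound 2 (2.32 log units; beyond the scatter). Because a 210-fold lower number from compound 1 to compound 2 (2.32 log units; beyond the scatter) was large, a step of similar direction is expected for compound 4, a 93-fold lower number from compound 3 to compound 4 (1.97 log units; beyond the scatter), though with wide uncertainty since the surroundings differ. Compound 4 is therefore estimated at 300 nM, within 40 nM to 5000 nM.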

Compound 4, half-maximal cytotoxic concentration: 19000 nM
The estimate for compound 4 lay 63-fold (1.80 log units) below the measured number; the whole stated range lies below it.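

In this assay, the swap of methoxy for amino does not carry over from the core of compound 1 to the core of compound 3: here the step is a 1.5-fold lower number from compound 3 to compound 4 (0.17 log units; within the scatter), so this swap cannot be told apart from repeat-measurement noise on this core. Set side by side, the two results show that the size of this step depends on the core it is made on, as two steps that should match if the change carried over do not: the same change on two cores in this assay, a 210-fold lower number (2.32 log units; beyond the scatter) from compound 1 to compound 2 and a 1.5-fold lower number (0.17 log units; within the scatter) from compound 3 to compound 4, 140-fold (2.15 log units) apart, beyond the scatter of two such steps

This does not show which difference between the two cores matters, as the ring carrying the change has 3 nitrogen in compound 1 and 2 nitrogen in compound 3, while the two cores also differ elsewhere, including nitrile against chloro and the further methoxy group. With these two pairs alone, no rule can be drawn for any other core, and the steep step from compound 1 to compound 2 remains a single case.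

As far as these compounds go, it remains open whether a methylamino or dimethylamino group in the same place would follow amino on either core. From the compounds shown here alone, it is also open whether swapping the nitrile for chloro, with the rest of compound 2 kept, would leave the number of compound 2 where it stands.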